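This account rests on a few compounds, and the source may have more. Where it says the series, first, only, none or still open, it means among the compounds named here.

Measured compounds in this series:

Compound 1 `COc1cccc(Cn2cc(-c3ccc4ccccc4c3)nn2)c1`. In a functional assay on B16 cells (Mus musculus) for cytotoxicity, read by MTT assay, with a stated time of 48 h (on this read-out higher numbers stand for weaker inhibition and lower numbers for stronger inhibition), compound 1 gives > 100000 nM, which is a limit of the assay and not a number.
Compound 2 `CCOC(=O)Cn1cc(-c2ccc3ccccc3c2)nn1`. In this assay compound 2 gives > 100000 nM, again a limit of the assay.
Compound 3 `COc1ccc(C(O)c2cn(CCCO)nn2)c(OC)c1OC`. In this assay compound 3 gives > 100000 nM, also a limit of the assay.

Compound 2 therefore stands at the limit, as do the other two members, so that every value shown sits at the limit of > 100000 nM in this assay, at which 3 of the 3 values shown sit. Among the measured compounds shown here, the only measured step between neighbours, a step that the two limits leave unreadable from compound 1 to compound 2, is one that the two limits leave unreadable; it gives no size and no direction.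

Compound 4 `CC1(C)OCC(Cn2cc(-c3ccc4ccccc4c3)nn2)O1` is not yet measured. It differs from compound 2 by 2,2-dimethyl-1,3-dioxolan-4-yl in place of ethoxycarbonyl on a saturated chain carbon bound to an aromatic nitrogen. For the measured compounds named here, no measured step bears readably on this change; the single step available is unreadable, and compound 3, which carries a different chain on the same kind of carbon, also sits at the limit.

For compound 4 in this assay the expected outcome is again a limit, with an estimate of 150000 nM in a range of 50000 nM to 500000 nM. The step that the limit leaves unreadable from compound 2 to compound 4 is expected to show no change beyond the scatter.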

Compound 4, half-maximal inhibitory concentration: 6600 nM
The estimate for compound 4 lay 23-fold (1.36 log units) above the measured number; the whole stated range lies above it.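

Among the compounds shown here, on the saturated chain carbon bound to an aromatic nitrogen, the choice of group is the first change to give a readable effect in this assay. 2,2-Dimethyl-1,3-dioxolan-4-yl in place of ethoxycarbonyl gives an at least 15-fold lower number from compound 2 to compound 4 (1.18 log units; beyond the scatter), and the same group in place of 3-methoxyphenyl gives an at least 15-fold lower number from compound 1 to compound 4 (1.18 log units; beyond the scatter). Only compound 4 leaves the limit, which holds the rest of the compounds shown: the limit of > 100000 nM in this assay, at which 3 of the 4 values shown sit.

Whether the ring, its two methyl groups or its oxygens carry this drop stays open, as the compounds shown place neither a 2,3-dihydroxypropyl chain nor a cyclopentyl ring on this carbon. On these data alone, the full size of both steps also stays open, since the results for compound 1 and compound 2 are limits and not numbers.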